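The source may report more compounds than this note shows. Statements on the series, on what has been measured and on what is new or still open speak of the compounds shown alone.

Of the compounds shown here, three sharing one core have been measured for their ability to slow the growth of a human melanoma cell line. Compound 1 `O=C(Nc1cc(-c2ccccc2)[nH]n1)c1cccnc1Cl` gives 6220 nM in a functional assay on WM 266-4 cells (Homo sapiens) for antiproliferative activity, read by MTT assay, with a stated time of 48 h; on this read-out higher numbers stand for weaker inhibition and lower numbers for stronger inhibition. Compound 2 `COc1ncccc1C(=O)Nc1cc(-c2ccccc2)[nH]n1` differs from compound 1 by methoxy in place of chloro on an aromatic carbon and in this assay compound 2 gives 8750 nM, which is a 1.4-fold higher number from compound 1 to compound 2 (0.15 log units; within the scatter). Compound 3 `O=C(Nc1cc(-c2ccccc2)[nH]n1)c1ccc(Cl)nc1` holds the same atoms as compound 1 joined differently, the difference being (6-chloropyridin-3-yl in place of 2-chloropyridin-3-yl on a carbonyl carbon), and in this assay compound 3 gives 6430 nM, which is a 1.0-fold higher number from compound 1 to compound 3 (0.01 log units; within the scatter). All three values thus sit within the usual scatter of one another, and none can be called stronger or weaker than the others.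

Compound 4 `COc1ccc(C(=O)Nc2cc(-c3ccccc3)[nH]n2)cn1` has not yet been measured. It stands to compound 3 as compound 2 stands to compound 1: the change is methoxy in place of chloro on an aromatic carbon. In compound 2 the methoxy sits ortho to a large group, whereas in compound 4 it sits para to a large group, so this is the same kind of change rather than the same change. Because a 1.4-fold higher number from compound 1 to compound 2 (0.15 log units; within the scatter) was within the scatter, the step from compound 3 to compound 4 is expected to be small as well, about a 1.3-fold higher number from compound 3 to compound 4 (0.12 log units; within the scatter). In this assay, going by the values given here, compound 4 is therefore estimated at 8500 nM, with a likely range from 4500 nM to 16000 nM, an expectation resting on compound 3 at 6430 nM and on the single earlier instance of the change.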

Compound 4, half-maximal inhibitory concentration: 8480 nM
Compound 4: middle estimate off by 1.0-fold (0.00 log units), on the high side; the measured number falls inside the stated range.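

In this assay, putting methoxy in place of chloro on the aromatic carbon gives a 1.3-fold higher number from compound 3 to compound 4 (0.12 log units; within the scatter), so the swap again leaves the number essentially where it was. Set beside the earlier case, the two steps agree: the same change on two cores in this assay, a 1.4-fold higher number (0.15 log units; within the scatter) from compound 1 to compound 2 and a 1.3-fold higher number (0.12 log units; within the scatter) from compound 3 to compound 4, 1.1-fold (0.03 log units) apart, within the scatter of two such steps

This shows that, across the two cores seen here, the change behaved the same way, and that the result from one core would have been a fair guide to the other. It does not show that methoxy and chloro are interchangeable in general: both steps lie within the scatter, so any small real difference between the two groups cannot be seen, and two pairs in a single cell assay say nothing about other cores, other positions on the ring or other kinds of test.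

The compounds shown carry only chloro or methoxy at these places, so it remains open whether an amine, a carboxylic acid or a longer chain such as butoxy would move the number beyond the scatter. As far as these compounds go, it is also open whether any change elsewhere on the shared core would give a larger step than this swap does.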